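This account rests on a few compounds, and the source may have more. Where it says the series, first, only, none or still open, it means among the compounds named here.

Measured so far in a functional assay on K562 cells (Homo sapiens) for antiproliferative activity, read by MTT assay, with a stated time of 48 h; on this read-out lower numbers stand for stronger inhibition and higher numbers for weaker inhibition:
- compound 1, `CNc1nc(Nc2cnn(CCCCCCC(=O)NO)c2)ncc1Cl`: 590 nM
- compound 2, `O=C(CCCCCCn1cc(Nc2ncc(Cl)c(Nc3ccc(F)cc3)n2)cn1)NO`: 500 nM

For the measured compounds named here, compound 2 carries the lower of the two numbers, but the only step between them is a 1.2-fold lower number from compound 1 to compound 2 (0.07 log units; within the scatter), so the two compounds cannot be told apart on this read-out. Going by the values given here, that single step, swapping methyl for 4-fluorophenyl on a ring nitrogen, is the only comparison available and it does not touch the change now in question.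

Compound 3, `O=C(CCCCCCn1cc(Nc2ncc(Cl)c(Nc3ccccc3)n2)cn1)NO`, differs from compound 2 by hydrogen in place of fluoro on an aromatic carbon. Among the compounds with values here, no measured step removes or adds a fluoro on this phenyl, so there is nothing in the numbers to set a direction; the change is small and the series has so far been flat. The step of no change at the digits printed from compound 2 to compound 3 (within the scatter) is therefore expected to stay within the scatter. Compound 3 is estimated at 500 nM, with a range of 250 nM to 1000 nM.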

Compound 3, half-maximal inhibitory concentration: 420 nM
Beside the measured number, compound 3's estimate is 1.2-fold (0.08 log units) above it; the range from low to high includes it.
By their numbers in this assay, from the lowest: compounds 3, 2 and 1 (each within the scatter of the next).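

In this assay, hydrogen in place of fluoro on an aromatic carbon, para to a large group, gives a 1.2-fold lower number from compound 2 to compound 3 (0.08 log units; within the scatter), so this change on the phenyl ring does not separate the two compounds. Phenyl in place of methyl gives a 1.4-fold lower number from compound 1 to compound 3 (0.15 log units; within the scatter), which is also within the scatter and, with the earlier 4-fluorophenyl step, leaves neither aryl group distinguishable from methyl on this read-out. Nothing available explains why these changes leave the read-out flat.

Going by these compounds, it remains open whether a different group on this aromatic carbon, such as methoxy, trifluoromethyl or an amine, would move the number beyond the scatter. The compounds shown also leave open what a longer chain would do in place of the one they all share.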